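The source may report more compounds than this note shows. Statements on the series, on what has been measured and on what is new or still open speak of the compounds shown alone.

Measured so far in an ADME assay on MT4 cells (Homo sapiens) for cytotoxicity, read by MTT assay; a higher number here means that more compound is tolerated, a lower number that less compound is tolerated:
- compound 1, `Cc1ccccc1NC(=O)CSc1nccn1-c1cccc2ccccc12`: compound 1 gives 34600 nM
- compound 2, `O=C(CSc1nccn1-c1cccc2ccccc12)Nc1ccccc1[N+](=O)[O-]`: compound 2 gives 28800 nM

Going by the values given here, compound 2 holds the lowest of the two numbers in this assay, but only narrowly: the single measured step, a 1.2-fold lower number from compound 1 to compound 2 (0.08 log units; within the scatter), lies within the scatter, so compound 1 and compound 2 cannot be told apart on these data.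

Compound 3, `O=C(CSc1nccn1-c1cccc2ccccc12)Nc1ccccc1Cl`, is the next member. It differs from compound 2 by chloro in place of nitro on an aromatic carbon.

Among the compounds with values here, the one step that bears on this change is the exchange at the same aromatic carbon, a 1.2-fold lower number from compound 1 to compound 2 (0.08 log units; within the scatter), which did not move the number beyond the scatter. Within the data shown here, nothing measured so far speaks for the chloro group behaving differently from the methyl or nitro group at this place, so no step beyond the scatter is expected in this assay either.

Compound 3 is therefore estimated at 30000 nM, with a range from 15000 nM to 60000 nM. Among the measured compounds shown here, the step this implies, a 1.0-fold higher number from compound 2 to compound 3 (0.02 log units; within the scatter), is expected to stay within the scatter, because the only comparable step, a 1.2-fold lower number from compound 1 to compound 2 (0.08 log units; within the scatter), did so.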

Compound 3, half-maximal cytotoxic concentration: 35200 nM
The estimate for compound 3 lay 1.2-fold (0.07 log units) below the measured number, and the stated range covers the measured number.
By their numbers in this assay, from the lowest: compounds 2, 1 and 3 (each within the scatter of the next).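

In this assay, chloro in place of nitro on this aromatic carbon gives a 1.2-fold higher number from compound 2 to compound 3 (0.09 log units; within the scatter), and chloro in place of methyl at the same place gives a 1.0-fold higher number from compound 1 to compound 3 (0.01 log units; within the scatter). With these steps, all three pairs among compound 1, compound 2 and compound 3 are within the scatter, so the three groups cannot be told apart at this place, even though the change from nitro to chloro goes from 3 heavy atoms and 2 hydrogen-bond acceptors to 1 heavy atom and no hydrogen-bond acceptors. No measurement at hand gives a reason for this lack of separation.

Open, going by these compounds, is whether an amine, a carboxylic acid or a longer chain on this aromatic carbon would give a step beyond the scatter in this assay. Also open, on these data alone, is whether methyl, nitro and chloro would remain indistinguishable at another carbon of the six-membered aromatic ring, or with a change elsewhere in the shared core.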